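The compounds below may be only part of what the source reports. "The series", "measured", "known", "first", "only" and "open" are said of these compounds alone.

Among the compounds with values here, in a functional assay on EC9706 cells (Homo sapiens) for antiproliferative activity, read by MTT assay, with a stated time of 48 h (on this read-out higher numbers stand for weaker inhibition and lower numbers for stronger inhibition), compound 3 `CCCCCCCCCCn1cc(COC[C@@H]2OC[C@H](N)[C@H]2O)nn1` gives 43100 nM, the higher of the two exact numbers so far. Compound 1 `CCCCCCCCCCn1cc(COC[C@@H]2OC[C@H](N)[C@@H]2O)nn1` gives 15600 nM. Compound 2 `CCCCCCCCCn1cc(COC[C@@H]2OC[C@H](N)[C@H]2O)nn1` gives only a limit, > 128000 nM.

Compound 4 `CCCCCCCCCCCCCCCCCCn1cc(COC[C@@H]2OC[C@H](N)[C@H]2O)nn1` extends the chain of compound 3: octyl in place of hydrogen on a saturated chain carbon, ten or more bonds along the chain from an aromatic nitrogen. The closest guide is methyl in place of hydrogen on the same chain, an at least 2.9-fold lower number from compound 2 to compound 3 (0.47 log units; beyond the scatter), which lowered the number. The other measured step, a 2.8-fold higher number from compound 1 to compound 3 (0.44 log units; beyond the scatter), changes configuration and leaves the chain alone, so it offers little guidance here. A single methyl is thin evidence for an octyl change, so only a modest further fall in this assay is expected. The estimated change is a 2.4-fold lower number from compound 3 to compound 4 (0.38 log units; beyond the scatter). Compound 4 is expected at 18000 nM, within an estimated range of 4000 nM to 80000 nM.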

Compound 4, half-maximal inhibitory concentration: 2290 nM
Estimate against measurement, compound 4: 7.9-fold (0.90 log units) above, and the stated range ends above it.
By their numbers in this assay, from the lowest: compound 4; then compound 1; then compound 3. At a limit, above all of these: compound 2.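

Extending the chain at this position counts for far more than the single methyl suggested: in this assay the octyl change gives a 19-fold lower number from compound 3 to compound 4 (1.27 log units; beyond the scatter). Over the full span of chains the change is an at least 55-fold lower number from compound 2 to compound 4 (1.74 log units; beyond the scatter), a size that is only a minimum because its starting value is a limit: the limit of > 128000 nM in this assay, at which 1 of the 4 values shown sits. Among the three compounds sharing one configuration as drawn, a longer chain goes with a lower number.

A dodecyl or tetradecyl chain would show whether this fall is steady or abrupt, and a still longer chain whether it continues. From the compounds shown here alone, whether the configuration of compound 1 gives the same gain on a long chain also remains open.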